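Methoxy for chloro on a hydrazone of a thiazole

The source may report more compounds than this note shows. Statements on the series, on what has been measured and on what is new or still open speak of the compounds shown alone.

Of the compounds shown here, three on a shared core have been measured in an assay on mitochondria for inhibition of Amine oxidase [flavin-containing] B (Bos taurus); on this read-out higher numbers stand for weaker inhibition and lower numbers for stronger inhibition. Compound 1 `Cc1csc(N/N=C/c2ccccc2)n1` gives 1.32 nM. Compound 2 `Cc1csc(N/N=C/c2ccc(Cl)cc2)n1` gives 9.12 nM, the second highest of the three numbers: its nearest neighbour is compound 1, and the step of a 6.9-fold higher number from compound 1 to compound 2 (0.84 log units; beyond the scatter) corresponds to a chloro in place of hydrogen on an aromatic carbon. Compound 3 `Clc1ccc(/C=N/Nc2nc(-c3ccccc3)cs2)cc1` gives 170 nM, the furthest from compound 2, reached through a 19-fold higher number from compound 2 to compound 3 (1.27 log units; beyond the scatter) when a phenyl replaces the methyl on the core.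

Compound 4 `COc1ccc(/C=N/Nc2nc(C)cs2)cc1` has not yet been measured. It differs from compound 2 by methoxy in place of chloro on an aromatic carbon. Among the measured compounds shown here, of the measured steps, only the one from compound 1 to compound 2 concerns the same position, and it was modest; the large step to compound 3 concerns the other end of the molecule and says nothing about this change. For the measured compounds named here, no measured compound carries a methoxy, so the direction is open. Compound 4 is therefore expected to sit near compound 2, with a step of a 1.5-fold lower number from compound 2 to compound 4 (0.18 log units; within the scatter) in this assay. The estimate for compound 4 is 6 nM, within a range from 1.5 nM to 30 nM.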

Compound 4, inhibition constant: 4.07 nM
Compound 4: the middle estimate sits 1.5-fold (0.17 log units) above what was measured, and the stated range covers the measured number.
By their numbers in this assay, from the lowest: compound 1; then compound 4; then compound 2; then compound 3.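

In this assay, among the compounds shown here, the earlier compounds showed only that chloro on this aromatic carbon, para to a group of 9 heavy atoms, gives a higher number than hydrogen; the new result adds a second group at the same place, with a 2.2-fold lower number from compound 2 to compound 4 (0.35 log units; beyond the scatter) when methoxy takes the place of chloro. The read-out at this position therefore depends on which group stands there and not only on whether hydrogen has been replaced, yet methoxy does not recover the number of the unsubstituted compound, as a 3.1-fold higher number from compound 1 to compound 4 (0.49 log units; beyond the scatter) shows, so hydrogen remains the lowest of the three groups placed here. Nothing in the data explains why methoxy and chloro differ at this position.

The compounds shown leave open whether another group on this carbon, such as an amine, a carboxylic acid or a longer chain like butoxy, would fall below the unsubstituted compound or rise above the chloro compound. They also leave open whether methoxy in place of chloro would give a similar step on the phenyl-bearing core of compound 3, where only chloro appears at this position.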